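The source may hold more compounds than are shown below. What is called first, only, known or untested is meant among the compounds shown, and "the series" means these compounds.

Working notes on the series. Among the measured compounds shown here, compound 1 `N#Cc1cc(-c2nc3ccc(F)cc3s2)ccc1N` gives 820 nM in a functional assay on MCF7 cells (Homo sapiens) for inhibition, with a stated time of 72 h (a lower number here means a stronger inhibitor of growth, a higher number a weaker inhibitor of growth), and stands at the highest of the three numbers measured so far. Compound 2 `N#Cc1cc(-c2nc3ccccc3s2)ccc1N` gives 580 nM in this assay; the step of a 1.4-fold lower number from compound 1 to compound 2 (0.15 log units; within the scatter) is hydrogen in place of fluoro on an aromatic carbon. Compound 3 `C#Cc1cc(-c2nc3cc(F)ccc3s2)ccc1N` gives 11 nM in this assay. Compound 3 and compound 1 differ at more than one place, so their two values are only set side by side: the gap between them is large and lies far beyond the scatter.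

Compound 4 `C#Cc1cc(-c2nc3ccc(F)cc3s2)ccc1N` is not yet measured. It differs from compound 1 by ethynyl in place of cyano on an aromatic carbon. For the measured compounds named here, no measured step isolates this exchange. Going by the values given here, the only single-site step on record, a 1.4-fold lower number from compound 1 to compound 2 (0.15 log units; within the scatter), concerns the fluoro and sits within the scatter, so it says nothing about the cyano-to-ethynyl change. Compound 3 carries the ethynyl and shows 11 nM, while compound 1 carries the cyano and shows 820 nM; the two also differ in the placement of the fluoro, so the comparison is loose. Among the compounds with values here, still, the ethynyl compound is the one with the low number. Compound 4 is therefore expected to land near 20 nM, within a range from 5 nM to 100 nM. That estimate means an expected step of a 41-fold lower number from compound 1 to compound 4 (1.61 log units; beyond the scatter) in this assay, downward and beyond the scatter.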

Compound 4, concentration for 50% growth inhibition: 110 nM
Beside the measured number, compound 4's estimate is 5.5-fold (0.74 log units) below it; the whole stated range lies below it.
By their numbers in this assay, from the lowest: compound 3; then compound 4; then compounds 2 and 1 (each within the scatter of the next).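

In this assay, among the compounds shown here, the step of a 7.5-fold lower number from compound 1 to compound 4 (0.87 log units; beyond the scatter) gives the first clean reading of ethynyl in place of cyano on an aromatic carbon ortho to an amino group, with the rest of the molecule unchanged, and it shows that this position responds to the exchange beyond the scatter. The exchange alone does not reach the lowest number in the series: compound 4 gives 110 nM and compound 3, which carries the same ethynyl with the fluoro placed elsewhere on the core, gives 11 nM in this assay. No measurement in hand accounts for the change at this position.

On these data alone, this reading rests on a single pair, so whether the step keeps its size without the fluoro or with the fluoro placed as in compound 3 remains open. The compounds shown also leave open how a methyl group, a chloro group, a propynyl chain or a carboxylic acid at this position would compare with ethynyl and cyano.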